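The compounds below may be only part of what the source reports. "The series", "measured", "known", "first", "only" and "open" are said of these compounds alone.

Measured in a functional assay on KG-1 cells (Homo sapiens) for cytotoxicity, read by luminescence and CellTiter-Glo, with a stated time of 3 days; a lower number here means a stronger inhibitor, a higher number a weaker inhibitor:
- compound 1 `Cc1ccc(C(=O)Nc2ccc(C#N)cc2)c(O)c1` gives 2560 nM
- compound 2 `N#Cc1ccc(NC(=O)c2ccc3cccnc3c2O)cc1` gives 2320 nM
- compound 3 `O=C(Nc1ccc(C(F)(F)F)cc1)c1ccc2cccnc2c1O` gives 3510 nM

The three values form a tight group. Compound 1 , at 2560 nM, lies within the scatter of both other compounds, so it cannot be ranked against either of them.

Compound 4 `N#Cc1ccc(NC(=O)c2ccc(-c3ccccc3)cc2O)cc1` is the next to be measured in this assay. It carries phenyl in place of methyl on an aromatic carbon, meta to a hydroxy group and para to a large group, and otherwise matches compound 1 (phenyl in place of methyl on an aromatic carbon).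

Only one measured step connects two of these compounds, and it bears on this change only indirectly. The change from cyano to trifluoromethyl gave a 1.5-fold higher number from compound 2 to compound 3 (0.18 log units; within the scatter), and it leaves the methyl site untouched. For the measured compounds named here, no measured pair shows what replacing the methyl does, so the size of this step remains open. The narrow spread of the measured values, with compound 3 at 3510 nM, gives no basis for expecting a shift in either direction beyond the scatter.

The expected change is a 1.2-fold lower number from compound 1 to compound 4 (0.07 log units; within the scatter), and this estimate carries wide uncertainty. For compound 4 the estimated value is 2200 nM, with an expected range from 800 nM to 6000 nM.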

Compound 4, half-maximal inhibitory concentration: 410 nM
Estimate against measurement, compound 4: 5.4-fold (0.73 log units) above; measured number below the stated range.
By their numbers in this assay, from the lowest: compound 4; then compounds 2, 1 and 3 (each within the scatter of the next).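

In this assay, the aromatic carbon meta to a hydroxy group and para to a large group proves responsive to what it carries: phenyl in place of methyl gives a 6.2-fold lower number from compound 1 to compound 4 (0.80 log units; beyond the scatter). For the compounds shown here, the earlier compounds could not show this, as their one measured step, a 1.5-fold higher number from compound 2 to compound 3 (0.18 log units; within the scatter), lay within the scatter and left this site untouched. The new step shows that this site accepts a six-membered aromatic ring of carbon only in place of a single carbon, with a lower number rather than a loss, although nothing available here bears on why the number falls.

The compounds shown leave open whether the gain needs phenyl itself or would also come with ethyl, cyclohexyl or a pyridine ring at this site, and whether an amine or a carboxylic acid on the added ring would keep it. They also leave open whether the step would hold with trifluoromethyl in place of cyano, and how far it depends on the rest of the core of compound 4.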